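Agonist series: the group on the saturated chain carbon

This account rests on a few compounds, and the source may have more. Where it says the series, first, only, none or still open, it means among the compounds named here.

Measured so far:
Compound 1 `O=C(O)c1ccccc1-c1ccc(CCc2ncc(CC3CCCCC3)[nH]2)cc1` gives 7.3 nM in an in vitro functional assay on cells for agonist activity at Bombesin receptor subtype-3 (Mus musculus), read by luminescence and calcium flux; a lower number here means that less compound is needed, a higher number that more compound is needed for the effect.
Compound 2 `Cc1ccccc1Cc1cnc(CCc2ccc(-c3ccccc3C(=O)O)cc2)[nH]1` gives 9.3 nM in this assay.
Compound 3 `COc1ccc(Cc2cnc(CCc3ccc(-c4ccccc4C(=O)O)cc3)[nH]2)cc1` gives 513 nM in this assay.

Compound 3 stands highest of the three numbers. The step of a 70-fold higher number from compound 1 to compound 3 (1.85 log units; beyond the scatter) and the step of a 55-fold higher number from compound 2 to compound 3 (1.74 log units; beyond the scatter) are both large and beyond the scatter, whereas a 1.3-fold higher number from compound 1 to compound 2 (0.11 log units; within the scatter) is within the scatter: the cyclohexyl and the 2-methylphenyl sit together, the 4-methoxyphenyl far above them.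

Compound 4 `O=C(O)c1ccccc1-c1ccc(CCc2ncc(Cc3ccccc3Cl)[nH]2)cc1` carries the change (2-chlorophenyl in place of 4-methoxyphenyl on a saturated chain carbon bound to an aromatic carbon). Going by the values given here, of the measured steps, the one from compound 2 to compound 3 bears most directly on it, since a 2-methylphenyl and a 2-chlorophenyl are both six-membered aromatic rings with a single substituent and no hydrogen-bond acceptor, and that step was large. Removing the 4-methoxyphenyl is therefore expected to undo most of that rise, giving a large step down in this assay, about a 34-fold lower number from compound 3 to compound 4 (1.53 log units; beyond the scatter). Among the compounds with values here, on this reasoning compound 4 is estimated at 15 nM, with a range from 4 nM to 80 nM, the uncertainty reflecting that no chlorine-bearing group has yet been measured.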

Compound 4, half-maximal effective concentration: 22 nM
Estimate against measurement, compound 4: 1.5-fold (0.17 log units) below; measured number inside the range.
By their numbers in this assay, from the lowest: compounds 1 and 2 (each within the scatter of the next); then compound 4; then compound 3.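

In this assay a chlorine-bearing group now appears at this saturated chain carbon, and 2-chlorophenyl in place of 4-methoxyphenyl gives a 23-fold lower number from compound 3 to compound 4 (1.37 log units; beyond the scatter) and so takes back most of the rise seen with the 4-methoxyphenyl. Compound 4 still does not join the low pair: chloro in place of methyl gives a 2.4-fold higher number from compound 2 to compound 4 (0.37 log units; beyond the scatter) and the change from cyclohexyl gives a 3.0-fold higher number from compound 1 to compound 4 (0.48 log units; beyond the scatter) even though those two groups sit within the scatter of each other. The large rise thus stays with compound 3 alone of the four, while the swap of one ring substituent still shows modestly in the number.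

Compound 3 and compound 4 differ both in the substituent and in where it sits on the ring, so a 4-chlorophenyl or a 2-methoxyphenyl would be needed to tell which of the two carries the large step. No measurement shown accounts for any of these differences.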